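A few compounds are considered here, and "the series" means these few. Any claim that something is new, unique, unknown or untested is made for them only; others in the source may bear on it.

Compound 1, `Cn1c(=O)n2c3c1c(=O)nc(N)n3CC1OC2[C@H](O)[C@@H]1O`: 6% in a functional assay on YAC-1 cells (Mus musculus); a lower number here means a smaller maximal response, a higher number a larger maximal response.
Compound 2, `C=CCn1c(=O)n(CCCC)c2nc(N)nc(O)c21`: 21%.
Compound 3, `N#Cc1cccc(Cn2c(=O)n(C3OC(CO)[C@@H](O)[C@H]3O)c3nc(N)nc(O)c32)c1`: 11%.

Among these three numbers compound 3 takes the second place, yet its gap to compound 1 and its gap to compound 2 both lie within the usual scatter, so the three compounds cannot be told apart on this evidence. All three give a small maximal response.

Compound 4, `Nc1nc(O)c2c(n1)n(C1OC(CO)[C@@H](O)[C@H]1O)c(=O)n2Cc1ccc([N+](=O)[O-])cc1`, has not been measured. It differs from compound 3 in one place: 4-nitrophenyl in place of 3-cyanophenyl on a saturated chain carbon bound to an aromatic nitrogen. Among the measured compounds shown here, no measured pair of compounds shows a change of this kind, so there is no step to lean on. The estimate therefore keeps compound 4 close to compound 3, with a step of no change at the digits printed from compound 3 to compound 4 (within the scatter) that is expected to stay within the scatter. Compound 4 is expected to give about 11%, between 3% and 25%.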

Compound 4, largest response reached (reported as maximal response), in percent of the reference or control that the assay uses: 50%
The estimate for compound 4 lay 39 percentage points below the measured number; measured number above the stated range.
By their numbers in this assay, from the lowest: compounds 1, 3 and 2 (each within the scatter of the next, the first and the last beyond it); then compound 4.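

In this assay, putting 4-nitrophenyl in place of 3-cyanophenyl on a saturated chain carbon bound to an aromatic nitrogen gives a number 39 percentage points higher from compound 3 to compound 4 (beyond the scatter). This position is therefore sensitive: one change to this group is enough to lift the response well clear of the low level of compound 3. No measurement at hand explains this step.

The swap alters both the group and the number in its name, so the compounds shown cannot separate the two. From the compounds shown here alone, how 4-cyanophenyl, 3-nitrophenyl or an unsubstituted phenyl would behave here stays open.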